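The source may report more compounds than this note shows. Statements on the series, on what has been measured and on what is new or still open speak of the compounds shown alone.

Measured so far in a functional assay on HONE1 cells (Homo sapiens) for cytotoxicity, read by sulforhodamine B assay, with a stated time of 24 h; on this read-out higher numbers stand for weaker inhibition and lower numbers for stronger inhibition:
compound 1 `COc1ccc(NC(=S)Nn2c(S)nnc2-c2ccncc2)cc1`, 2270 nM;
compound 2 `Cc1ccc(NC(=S)Nn2c(S)nnc2-c2ccncc2)cc1`, 1290 nM;
compound 3 `COc1ccc(Nc2nn3c(-c4ccncc4)nnc3s2)cc1`, 2220 nM.

Compound 2 differs from compound 1 by methyl in place of methoxy on an aromatic carbon, and in this assay that step reads a 1.8-fold lower number from compound 1 to compound 2 (0.25 log units; within the scatter). Compound 3 carries the same methoxy group as compound 1 but sits on a different core; the difference between the two cores is not broken down here. In this assay compound 3 gives 2220 nM, which lies within the scatter of compound 1.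

Compound 4 `Cc1ccc(Nc2nn3c(-c4ccncc4)nnc3s2)cc1` is not yet measured. It differs from compound 3 by methyl in place of methoxy on an aromatic carbon, the same change as from compound 1 to compound 2. In this assay the step from compound 3 to compound 4 is expected to be a 1.6-fold lower number from compound 3 to compound 4 (0.20 log units; within the scatter), because a 1.8-fold lower number from compound 1 to compound 2 (0.25 log units; within the scatter) stayed within the scatter for the same change. Compound 4 is therefore estimated at 1400 nM, expected between 700 nM and 2900 nM.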

Compound 4, half-maximal inhibitory concentration: 3280 nM
For compound 4 the middle estimate is 2.3-fold (0.37 log units) below the measured one; measured number above the stated range.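

In this assay, methyl in place of methoxy on the second core gives a 1.5-fold higher number from compound 3 to compound 4 (0.17 log units; within the scatter). Set beside the same change on the first core, the two steps do not differ by more than repeated measurements would: the same change on two cores in this assay, a 1.8-fold lower number (0.25 log units; within the scatter) from compound 1 to compound 2 and a 1.5-fold higher number (0.17 log units; within the scatter) from compound 3 to compound 4, 2.6-fold (0.41 log units) apart, within the scatter of two such steps. This shows no detectable dependence of the change on the core, but since each step is itself within the scatter, it does not show that the change has any effect on either core, nor that the two cores respond alike.

The compounds shown carry only methoxy or methyl at this place, so the effect of a chlorine atom, an amine or a carboxylic acid there remains open. Also open, as far as these compounds go, is how the change behaves on any core other than these two.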